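Adding hydroxymethyl to the piperidin-1-yl group of compound 3

A few compounds are considered here, and "the series" means these few. Any claim that something is new, unique, unknown or untested is made for them only; others in the source may bear on it.

Measured so far in a functional assay on MCF7 cells (Homo sapiens) for antiproliferative activity, read by MTT assay, with a stated time of 72 h; on this read-out lower numbers stand for stronger inhibition and higher numbers for weaker inhibition
- compound 1 (`COc1cc2ncnc(N3CCCc4ccccc43)c2cc1NC(=O)/C=C/C(C)C`) gives 4290 nM
- compound 2 (`COc1cc2ncnc(N3CCCc4ccccc43)c2cc1NC(=O)/C=C/CN1CCCC1`) gives 3190 nM
- compound 3 (`COc1cc2ncnc(N3CCCc4ccccc43)c2cc1NC(=O)/C=C/CN1CCCCC1`) gives 3930 nM

Compound 3 stands within the scatter of both other compounds, so no order can be read among the three. Compound 4 (`COc1cc2ncnc(N3CCCc4ccccc43)c2cc1NC(=O)/C=C/CN1CCC(CO)CC1`) differs from compound 3 by one change (hydroxymethyl in place of hydrogen on a saturated ring carbon): hydroxymethyl in place of hydrogen on a saturated ring carbon, three ring bonds from the ring nitrogen.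

The nearest evidence comes from the measured exchanges at the same chain end (a 1.3-fold lower number from compound 1 to compound 2 (0.13 log units; within the scatter); a 1.1-fold lower number from compound 1 to compound 3 (0.04 log units; within the scatter); a 1.2-fold higher number from compound 2 to compound 3 (0.09 log units; within the scatter)). All three lie within the scatter. Among the measured compounds shown here, none of them introduces hydroxymethyl, so they bear on this step only indirectly, and the series holds no direct precedent. As far as these compounds go, no step beyond the scatter is therefore expected in this assay, and the direction stays open.

The expected step is small (a 1.1-fold lower number from compound 3 to compound 4 (0.04 log units; within the scatter)). Compound 4 is estimated at 3600 nM in this assay, with an expected range from 1600 nM to 8000 nM.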

Compound 4, half-maximal inhibitory concentration: 5740 nM
Compound 4: middle estimate off by 1.6-fold (0.20 log units), on the low side; the range from low to high includes it.
By their numbers in this assay, from the lowest: compounds 2, 3, 1 and 4 (each within the scatter of the next).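

In this assay, among the compounds shown here, hydroxymethyl in place of hydrogen on the saturated ring carbon, three ring bonds from the ring nitrogen, gives the first direct reading at this position (a 1.5-fold higher number from compound 3 to compound 4 (0.16 log units; within the scatter)), and no effect can be claimed from a step within the scatter. The wider exchanges at the chain end, 4-(hydroxymethyl)piperidin-1-yl for pyrrolidin-1-yl (a 1.8-fold higher number from compound 2 to compound 4 (0.26 log units; within the scatter)) and (4-(hydroxymethyl)piperidin-1-yl)methyl for isopropyl (a 1.3-fold higher number from compound 1 to compound 4 (0.13 log units; within the scatter)), also stay within the scatter, so all four compounds remain unresolved in this assay. No supporting evidence is available to explain these numbers.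

The compounds shown leave open whether a carboxylic acid or a primary amine on this ring carbon would give a step beyond the scatter. They also leave open how a longer chain, such as hydroxyethyl, would read at this position.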